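This account rests on a few compounds, and the source may have more. Where it says the series, first, only, none or still open, it means among the compounds named here.

Compound 1 `Cc1cc(C#Cc2ccc(CCC(=O)O)cc2)nc(Cl)n1`, 110%; compound 2 `O=C(O)CCc1ccc(C#Cc2ccccn2)cc1`, 98%; compound 3 `Cc1cnc(F)cc1C#Cc1ccc(CCC(=O)O)cc1`, 99%.

In an in vitro functional assay on 1321-N1 cells for agonist activity at Free fatty acid receptor 1 (Homo sapiens), read by fluorescence, spectrophotometry and calcium flux (on this read-out higher numbers stand for larger maximal responses and lower numbers for smaller maximal responses), compound 1 gives 110%, the largest maximal response of the three. Compound 3 reaches 99%, a gap beyond the usual scatter, and compound 2 reaches 98%, the furthest of the three from compound 1, also beyond the scatter.

Compound 4 `O=C(O)CCc1ccc(C#Cc2ccnc(Cl)n2)cc1` differs from compound 1 in one place on the shared core: hydrogen in place of methyl on an aromatic carbon. Among the compounds with values here, no pair of measured compounds isolates this change, and all three values lie close to or above the reference response. A small step, if any, is expected in this assay. Compound 4 is expected to give 100%, with a range of 85% to 115%. This corresponds to an expected step of a number 10 percentage points lower from compound 1 to compound 4 (within the scatter), likely within the usual scatter.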

Compound 4, largest response reached (reported as efficacy), in percent of the reference or control that the assay uses: 131%
Compound 4: the middle estimate sits 31 percentage points below what was measured, outside the stated range (above it).
By their numbers in this assay, from the lowest: compounds 2 and 3 (each within the scatter of the next); then compound 1; then compound 4.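

Hydrogen in place of methyl on this aromatic carbon, next to the ring nitrogen, gives in this assay a clear change: a number 21 percentage points higher from compound 1 to compound 4 (beyond the scatter). Within the data shown here, this is the first single-place comparison, and it shows that the methyl is not required at this position for a full maximal response, and that the response on this core depends on what sits there. Nothing available explains the step. Going by these compounds, whether a methoxy group or an amine at this position would give a larger or smaller response remains open. So does whether the same step would appear with a group other than the chloro group on the ring.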